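A few compounds are considered here, and "the series" means these few. Any claim that something is new, unique, unknown or untested is made for them only; others in the source may bear on it.

Measured compounds:
compound 3 `Cc1nc(-c2ccc(C(F)(F)F)cc2)sc1COc1ccc([C@H](CC(=O)O)c2nnnn2C)cc1` — 3.8 nM
compound 1 `CC#C[C@@H](CC(=O)O)c1ccc(OCc2cccc(-c3ccc(Cl)cc3C)c2)cc1` — "not determined" (no result reported)
compound 2 `Cc1nc(-c2ccc(C(F)(F)F)cc2)sc1COc1ccc([C@H](CC(=O)O)c2ncnn2C)cc1` — "not determined" (no result reported)

Going by the values given here, in a functional assay on A9 cells for agonist activity at Free fatty acid receptor 1 (Homo sapiens), read by inositol phosphate accumulation (on this read-out lower numbers stand for an effect already at smaller amounts and higher numbers for an effect only at larger amounts of compound), compound 3 gives 3.8 nM, the only number in this set; compound 1 gives "not determined" (no result reported) and compound 2 gives "not determined" (no result reported), so no comparison between measured compounds is possible and no step size has been observed. Compound 4 `Cc1nc(-c2ccc(C(F)(F)F)cc2)sc1COc1ccc([C@H](CC(=O)O)c2cnco2)cc1` is the next compound to be measured. It differs from compound 3 by 1,3-oxazol-5-yl in place of 1-methyl-1H-tetrazol-5-yl on a saturated chain carbon bound to an aromatic carbon and a saturated chain carbon. With nothing to anchor the step, a modest loss is expected rather than none, and the expected step from compound 3 to compound 4 is a 2.4-fold higher number from compound 3 to compound 4 (0.37 log units; beyond the scatter). Compound 4 is therefore estimated at 9 nM, within a range from 2.5 nM to 40 nM in this assay.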

Compound 4, half-maximal effective concentration: 9 nM
For compound 4 middle estimate and measured number coincide at the digits printed, within the range that was stated.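

In this assay the place on a saturated chain carbon bound to an aromatic carbon and a saturated chain carbon now has its first readable change: 1,3-oxazol-5-yl in place of 1-methyl-1H-tetrazol-5-yl gives a 2.4-fold higher number from compound 3 to compound 4 (0.37 log units; beyond the scatter) and so carries a modest cost. A five-membered aromatic ring with 2 hetero atoms thus keeps activity here, though not fully. No measurement shown accounts for this step.

Steps involving compound 1 and compound 2 cannot be read. Going by these compounds, whether a non-ring group at this place, such as an amide or a nitrile, would hold the activity of compound 3 stays open.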